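The compounds below may be only part of what the source reports. "The series", "measured", "known", "first", "only" and "open" are said of these compounds alone.

The series is followed in a functional assay on A549 cells (Homo sapiens) for cytotoxicity, read by CCK-8 assay, with a stated time of 24 h; a higher number here means a weaker inhibitor, a lower number a stronger inhibitor. Compound 1, `C/C(=C\c1nc(-c2ccc(F)cc2)cs1)C(N)=O`, carries a fluorine on its outer aromatic ring and in this assay compound 1 gives 13200 nM. Compound 2, `C/C(=C\c1cc(-c2ccc(S(C)(=O)=O)cc2)cs1)C(N)=O`, has a different core and a methylsulfonyl on the outer ring. In this assay compound 2 reaches only a limit, > 50000 nM, and no number is known for it. Within the data shown here, this is the situation described by the limit of > 50000 nM in this assay, at which 1 of the 2 values shown sits, so compound 2 sits at the weak end of what the assay can report, while compound 1 stands as the one with a measured number.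

Compound 3, `COc1ccc(-c2csc(/C=C(\C)C(N)=O)c2)cc1`, keeps the core of compound 2 and differs only by methoxy in place of methylsulfonyl on an aromatic carbon. Among the measured compounds shown here, no measured step of this kind exists here, so any expectation rests on compound 2 alone. Since compound 2 shows only a limit, the step toward compound 3 cannot be anchored; a modest move toward a lower number is thought possible, but it may also stay beyond the scatter only in part, or not at all. The expected step is estimated as an at least 1.4-fold lower number from compound 2 to compound 3 (0.15 log units; that floor lies within the scatter). Compound 3 is expected to give about 35000 nM, within a range from 10000 nM to 100000 nM.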

Compound 3, half-maximal inhibitory concentration: > 50000 nM
Compound 3 ended at the assay's limit (the forecaster's own chance of this, stated with the estimate: 45%); middle value at least 1.4-fold (0.15 log units) away from the limit.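

In this assay compound 3 reaches only a limit, > 50000 nM. No step can be read between compound 2 and compound 3, because both stand at a limit: the limit of > 50000 nM in this assay, at which 2 of the 3 values shown sit.

The compounds shown leave open how far methoxy and methylsulfonyl on this core actually differ, and how either compares with compound 1.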